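From Phenoxy to Bromo on the Shared Core

The compounds below may be only part of what the source reports. "The series", "measured", "known", "first", "only" and "open" are said of these compounds alone.

In a functional assay on RAW264.7 cells (Mus musculus) for inhibition, read by Griess assay, with stated times of 3 h and 24 h (on this read-out lower numbers stand for stronger inhibition and higher numbers for weaker inhibition), compound 1 `C=C1CCC2[C@](C)(CO)[C@H](O)CC[C@@]2(C)[C@@H]1CCOc1cccc2ccccc12` gives 44700 nM. Compound 2 `C=C1CCC2[C@](C)(CO)[C@H](O)CC[C@@]2(C)[C@@H]1CCOc1ccc(Oc2ccccc2)cc1` gives 12800 nM, the lower of the two numbers, with a gap beyond the scatter. Compound 3 `C=C1CCC2[C@](C)(CO)[C@H](O)CC[C@@]2(C)[C@@H]1CCOc1ccc(Br)cc1` differs from compound 2 in one place: bromo in place of phenoxy on an aromatic carbon, with bromo in place of phenoxy on an aromatic carbon. For the measured compounds named here, no measured pair shows this change alone, so the expectation is only a judgement from the lower number of compound 2 at 12800 nM. The estimated move is upward, toward weaker inhibition, with a 1.7-fold higher number from compound 2 to compound 3 (0.24 log units; within the scatter) expected. For compound 3 the estimated value is 22000 nM, with an expected range from 9000 nM to 50000 nM.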

Compound 3, half-maximal inhibitory concentration: 40300 nM
Estimate against measurement, compound 3: 1.8-fold (0.26 log units) below, within the range that was stated.
By their numbers in this assay, from the lowest: compound 2; then compounds 3 and 1 (each within the scatter of the next).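

Putting bromo in place of phenoxy, on an aromatic carbon para to a large group, gives a 3.1-fold higher number from compound 2 to compound 3 (0.50 log units; beyond the scatter) in this assay on the shared core. For the compounds shown here, this is the first change here that can be read alone, and it shows that at this position bromo does not match phenoxy, with the step beyond the scatter. Nothing shown explains the direction of this step.

As far as these compounds go, whether an amine, a carboxylic acid or a methoxy group at this place would stand nearer compound 2 or compound 3 remains open.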